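A few compounds are considered here, and "the series" means these few. Any claim that something is new, unique, unknown or untested is made for them only; others in the source may bear on it.

Compound 1 `O=C(/C=C/c1ccc2c(c1)B(O)OC2)c1ccc(O)cc1` gives > 10 ug/mL in an ADME assay on L929 cells (Mus musculus) for cytotoxicity, read by resazurin assay, with a stated time of 72 h (on this read-out higher numbers stand for weaker inhibition and lower numbers for stronger inhibition), a limit of the assay.
Compound 2 `Cc1ccc(C(=O)/C=C/c2ccc3c(c2)B(O)OC3)cc1` gives > 10 ug/mL in this assay, a limit of the assay.
Compound 3 `O=C(/C=C/c1ccc2c(c1)B(O)OC2)c1ccco1` gives > 10 ug/mL in this assay, a limit of the assay.

None of the three measured compounds yields a number: every value sits at the limit of > 10 ug/mL in this assay, at which 3 of the 3 values shown sit. Compound 3 therefore stands at the assay limit, no different from its two neighbours. The steps a step that the two limits leave unreadable from compound 1 to compound 2, a step that the two limits leave unreadable from compound 1 to compound 3 and a step that the two limits leave unreadable from compound 2 to compound 3 are all unreadable, as each joins two limits, so they give no size and no direction.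

Compound 4 `Nc1cccc(C(=O)/C=C/c2ccc3c(c2)B(O)OC3)c1` is the next compound. It differs from compound 3 by 3-aminophenyl in place of furan-2-yl on a carbonyl carbon. The two measured steps that swap the group on the carbonyl carbon, a step that the two limits leave unreadable from compound 1 to compound 3 and a step that the two limits leave unreadable from compound 2 to compound 3, are the ones that bear on this change, and both are unreadable. No step beyond the scatter can therefore be expected in this assay, in either direction. The expectation for compound 4 is that it again sits at the assay limit, with an estimated value of 15 ug/mL (range 7 ug/mL to 40 ug/mL). The step this estimate implies is a step that the limit leaves unreadable from compound 3 to compound 4.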

Compound 4, half-maximal inhibitory concentration: 10 ug/mL
Compound 4: middle estimate off by 1.5-fold (0.18 log units), on the high side; low and high end bracket the measured number.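

On the carbonyl carbon, 3-aminophenyl gives the only true number among these compounds in this assay: compound 4 reads 10 ug/mL. That number falls at the same figure as the limit that caps the other compounds: the limit of > 10 ug/mL in this assay, at which 3 of the 4 values shown sit.

In this assay, on these data alone, the data give a number no higher from compound 3 to compound 4 (the limit leaves the size open) and a number no higher from compound 2 to compound 4 (the limit leaves the size open) and a number no higher from compound 1 to compound 4 (the limit leaves the size open) with no readable size for any of them, as each joins a number to a limit; whether the number is truly lower stays unknown.

As far as these compounds go, what the amino group itself contributes stays open, as does the role of its place on the ring, and a reading for 4-aminophenyl or plain phenyl on the carbonyl carbon would speak to both. From the compounds shown here alone, how a carboxylic acid or a longer chain there would read also stays open.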